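Moving a hydroxyl on a triaryl pyridine: compound 2 to 3

This account rests on a few compounds, and the source may have more. Where it says the series, first, only, none or still open, it means among the compounds named here.

Compound 1 `Oc1ccc(-c2cc(-c3cccc(O)c3)nc(-c3cccc(O)c3)c2)cc1` and compound 2 `Oc1ccc(-c2cc(-c3ccc(O)cc3)nc(-c3cccc(O)c3)c2)cc1` share a core carrying three hydroxyphenyl groups. In a functional assay on T47D cells (Homo sapiens) for cytotoxicity, read by CCK-8 assay, with a stated time of 4 days (a higher number here means a weaker inhibitor, a lower number a stronger inhibitor), compound 1 gives 2230 nM, and compound 2 gives 4470 nM, the higher of the two numbers; the step of a 2.0-fold higher number from compound 1 to compound 2 (0.30 log units; within the scatter) is within the scatter. Compound 3 `Oc1ccc(-c2cc(-c3ccc(O)cc3)nc(-c3ccccc3O)c2)cc1` differs from compound 2 by 2-hydroxyphenyl in place of 3-hydroxyphenyl on an aromatic carbon. For the measured compounds named here, the only measured step, the one from compound 1 to compound 2, is a hydroxyl shift of the same kind, and it stayed within the scatter, so the step of a 1.1-fold higher number from compound 2 to compound 3 (0.05 log units; within the scatter) is expected to be small as well. Compound 3 is therefore estimated at 5000 nM, within a range of 2000 nM to 15000 nM.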

Compound 3, half-maximal inhibitory concentration: 50000 nM
Compound 3: the middle estimate sits 10-fold (1.00 log units) below what was measured, outside the stated range (above it).
By their numbers in this assay, from the lowest: compounds 1 and 2 (each within the scatter of the next); then compound 3.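

In this assay, the position next to the ring nitrogen proves sensitive to where the hydroxyl sits: 2-hydroxyphenyl in place of 3-hydroxyphenyl gives an 11-fold higher number from compound 2 to compound 3 (1.05 log units; beyond the scatter). This takes compound 3 clear of compounds 1 and 2. A hydroxyl shift on this core can therefore matter, which the earlier step alone did not show. No measurement offered here accounts for this step. The compounds shown leave open whether 2-methoxyphenyl or 2-aminophenyl at this position would give a number like that of 2-hydroxyphenyl.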